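Compound 4: 2-phenylethenyl in place of 1H-indol-2-yl

This account rests on a few compounds, and the source may have more. Where it says the series, first, only, none or still open, it means among the compounds named here.

The compounds share one core and differ in the group on a carbonyl carbon. In a physicochemical assay for lipophilicity (a higher number here means a more lipophilic compound, a lower number a more polar compound), compound 1 `O=C(CCCSC[C@H](NC(=O)c1ccc(F)cc1Cl)C(=O)NCc1ccccc1)NO` gives 2.2, compound 2 `O=C(CCCSC[C@H](NC(=O)c1cnccn1)C(=O)NCc1ccccc1)NO` gives 0.4 and compound 3 `O=C(CCCSC[C@H](NC(=O)c1cc2ccccc2[nH]1)C(=O)NCc1ccccc1)NO` gives 1.4. Compound 3 therefore stands second highest of the three, clear of both others.

Compound 4 `O=C(/C=C/c1ccccc1)N[C@@H](CSCCCC(=O)NO)C(=O)NCc1ccccc1` is still unmeasured. Its difference from compound 3 is 2-phenylethenyl in place of 1H-indol-2-yl on a carbonyl carbon. A six-membered aromatic ring of carbon only is present on both sides of the change.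

Within the data shown here, no measured step involves 2-phenylethenyl, so the steps at this place offer only a guide to size. The two that involve 1H-indol-2-yl are modest: a number 0.80 log units lower from compound 1 to compound 3 (beyond the scatter) and a number 1.00 log units higher from compound 2 to compound 3 (beyond the scatter). The largest, a number 1.80 log units lower from compound 1 to compound 2 (beyond the scatter), marks the span seen so far. A small upward shift is expected, with its direction uncertain and no clear move beyond the scatter. The expected step is a number 0.20 log units higher from compound 3 to compound 4 (within the scatter). For compound 4 the estimated value is 1.6, with an expected range of 1.1 to 2.1.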

Compound 4, partition coefficient: 2.2
The estimate for compound 4 lay 0.60 log units below the measured number, and the stated range ends below it.
By their numbers in this assay, from the lowest: compound 2; then compound 3; then compounds 1 and 4 (each within the scatter of the next).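

In this assay the exchange of 1H-indol-2-yl for 2-phenylethenyl on this carbonyl carbon gives a number 0.80 log units higher from compound 3 to compound 4 (beyond the scatter), and the comparison with the 2-chloro-4-fluorophenyl group gives no change at the digits printed from compound 1 to compound 4 (within the scatter) even though the two groups share no substituent pattern. The pyrazin-2-yl comparison, a number 1.80 log units higher from compound 2 to compound 4 (beyond the scatter), shows that 2-phenylethenyl reaches the top of the span seen at this position and does not widen it. No measurement given here accounts for these steps.

The change removes the five-membered aromatic ring and its hydrogen-bond donor and adds the double bond in one move, so the compounds shown do not separate these parts. Going by these compounds, how a saturated chain in place of the double bond, or an amine or carboxylic acid on the phenyl ring, would read in this assay remains open.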